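Removing a Hydroxy Group from a Fused Aromatic Ring

A few compounds are considered here, and "the series" means these few. Any claim that something is new, unique, unknown or untested is made for them only; others in the source may bear on it.

Compound 1 `O=C1CC(c2cccs2)=NCC2(CN3CCC2CC3)N1`: 20%
Compound 2 `Oc1c(C2=NC3(CN2)CN2CCC3CC2)oc2ccccc12`: 32%
Compound 3 `c1ccc(C2=NC3(CN2)CN2CCC3CC2)cc1`: 11%

In an in vitro assay on SH-EP1 cells for displacement of a labelled ligand from Neuronal acetylcholine receptor; alpha4/beta2 (Homo sapiens), tested at 5 uM (a lower number here means less inhibition, a higher number more inhibition at the concentration tested (going by the name of the read-out)), compound 2 gives 32%, the highest of the three numbers; compound 1 sits below it beyond the scatter, and compound 3 lies further below, also beyond the scatter. Compound 4 `c1ccc2oc(C3=NC4(CN3)CN3CCC4CC3)cc2c1` has not yet been measured. It differs from compound 2 in a single place: hydrogen in place of hydroxy on an aromatic carbon The hydroxy leaves and a hydrogen takes its place on an aromatic carbon, so the fused ring system is otherwise unchanged.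

Going by the values given here, no measured pair shows exactly this change, so the expectation rests on the overall spread. Compound 3, whose aromatic ring carries nothing at all, gives 11%, the lowest of the three. With that in mind, a drop beyond the scatter is expected, about a number 15 percentage points lower from compound 2 to compound 4 (beyond the scatter) in this assay. Compound 4 is therefore estimated to give 17% in this assay, most likely between 5% and 32%.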

Compound 4, a percentage reported as inhibition, at one concentration (the size of the read-out at that concentration, not a potency): 4%
Compound 4: the middle estimate sits 13 percentage points above what was measured; measured number below the stated range.
By their numbers in this assay, from the lowest: compounds 4, 3 and 1 (each within the scatter of the next, the first and the last beyond it); then compound 2.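

Swapping the hydroxy for hydrogen gives a number 28 percentage points lower from compound 2 to compound 4 (beyond the scatter) in this assay, and this is the first direct reading of this change, with the rest of the molecule left the same. With compound 4 at 4% as the reference, the inhibition seen for compound 2 at the concentration tested is tied to this single group, on an aromatic carbon of the five-membered aromatic ring. Nothing shown here offers an explanation for the size of this step.

As far as these compounds go, whether a methoxy group, an amine or a fluorine atom on the same carbon would retain the inhibition of compound 2, or lose it as hydrogen does, remains open. From the compounds shown here alone, each number is also a reading at one concentration, so how far compound 2 and compound 4 differ in potency is still unknown.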